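Isopropylphenyl isomers and growth inhibition

The source may hold more compounds than are shown below. What is called first, only, known or untested is meant among the compounds shown, and "the series" means these compounds.

In a functional assay on MCF7 cells (Homo sapiens) for inhibition, read by CCK-8 assay, with a stated time of 48 h (on this read-out lower numbers stand for stronger inhibition of growth and higher numbers for weaker inhibition of growth), compound 1 (`CCc1ccc(Nc2nc(Nc3ccc(N4CCN(C)CC4)cn3)ncc2Cl)cc1`) gives 8230 nM and compound 2 (`CC(C)c1cccc(Nc2nc(Nc3ccc(N4CCN(C)CC4)cn3)ncc2Cl)c1`) gives 8640 nM, so compound 2 stands level with compound 1 within the scatter. Compound 3 (`CC(C)c1ccccc1Nc1nc(Nc2ccc(N3CCN(C)CC3)cn2)ncc1Cl`) carries 2-isopropylphenyl in place of 3-isopropylphenyl on a nitrogen on an aromatic ring. Among the compounds with values here, the only measured step, a 1.0-fold higher number from compound 1 to compound 2 (0.02 log units; within the scatter), also changes this aryl group and stays within the scatter. Within the data shown here, no measured compound carries 2-isopropylphenyl, so no direction can be drawn, and no shift beyond the scatter is expected in this assay. The expected change is an estimated 1.1-fold lower number from compound 2 to compound 3 (0.03 log units; within the scatter). Compound 3 is estimated at 8000 nM, with a range of 3500 nM to 20000 nM.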

Compound 3, concentration for 50% growth inhibition: 4360 nM
For compound 3 the middle estimate is 1.8-fold (0.26 log units) above the measured one, and the stated range covers the measured number.
By their numbers in this assay, from the lowest: compounds 3, 1 and 2 (each within the scatter of the next).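

2-isopropylphenyl in place of 3-isopropylphenyl on this nitrogen gives a 2.0-fold lower number from compound 2 to compound 3 (0.30 log units; within the scatter) in this assay and so stays within the scatter, as does the other new comparison, a 1.9-fold lower number from compound 1 to compound 3 (0.28 log units; within the scatter), against 4-ethylphenyl. Across the three compounds, neither moving the isopropyl group from the 3-isopropylphenyl to the 2-isopropylphenyl arrangement nor exchanging either for 4-ethylphenyl gives a shift beyond the scatter. Within the data shown here, no evidence on the compounds bears on this reading.

Still open, from the compounds shown here alone, is whether an amine or a carboxylic acid on this aryl ring would move the number beyond the scatter.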